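From pyrimidin-2-yl to 5-fluoropyridin-2-yl on the sulfonamide nitrogen

The source may report more compounds than this note shows. Statements on the series, on what has been measured and on what is new or still open speak of the compounds shown alone.

In a physicochemical assay for lipophilicity (on this read-out higher numbers stand for higher lipophilicity and lower numbers for lower lipophilicity), compound 1 (`Cn1nccc1-c1cc(C(F)(F)F)ccc1[C@H]1CCOc2cc(S(=O)(=O)Nc3nccs3)ccc21`) gives 2.2, compound 2 (`Cn1nccc1-c1cc(C(F)(F)F)ccc1[C@H]1CCOc2cc(S(=O)(=O)Nc3cccc(F)n3)ccc21`) gives 3.6 and compound 3 (`Cn1nccc1-c1cc(C(F)(F)F)ccc1[C@H]1CCOc2cc(S(=O)(=O)Nc3ncccn3)ccc21`) gives 3.7. Compound 3 shares the top of this short range with compound 2, the two being level within the scatter. Both stand well clear of compound 1: a number 1.40 log units higher from compound 1 to compound 2 (beyond the scatter) and a number 1.50 log units higher from compound 1 to compound 3 (beyond the scatter).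

Compound 4 (`Cn1nccc1-c1cc(C(F)(F)F)ccc1[C@H]1CCOc2cc(S(=O)(=O)Nc3ccc(F)cn3)ccc21`) carries 5-fluoropyridin-2-yl in place of pyrimidin-2-yl on a sulfonamide nitrogen. Within the data shown here, no measured compound carries this group. The closest evidence is compound 2, with 6-fluoropyridin-2-yl, where the exchange with pyrimidin-2-yl gave a number 0.10 log units higher from compound 2 to compound 3 (within the scatter). The two large steps both start from the 1,3-thiazol-2-yl of compound 1, a group not involved in this change, so they bear on it only weakly. No step beyond the scatter is therefore expected in this assay, and the estimated step is a number 0.10 log units lower from compound 3 to compound 4 (within the scatter). Compound 4 is estimated at 3.6, with an expected range of 3.2 to 4.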

Compound 4, distribution coefficient: 3.8
The estimate for compound 4 lay 0.20 log units below the measured number, and the stated range covers the measured number.
By their numbers in this assay, from the lowest: compound 1; then compounds 2, 3 and 4 (each within the scatter of the next).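

In this assay, 5-fluoropyridin-2-yl falls level with the other two six-membered aromatic rings on the sulfonamide nitrogen: a number 0.10 log units higher from compound 3 to compound 4 (within the scatter) and a number 0.20 log units higher from compound 2 to compound 4 (within the scatter). The series therefore gives no separation among pyrimidin-2-yl, 6-fluoropyridin-2-yl and 5-fluoropyridin-2-yl, whereas 1,3-thiazol-2-yl remains apart, with a number 1.60 log units higher from compound 1 to compound 4 (beyond the scatter). No measurement at hand accounts for either the level group or the gap to 1,3-thiazol-2-yl.

Open, on these data alone, is whether the same level holds for a pyridin-2-yl carrying no fluorine or a chlorine in place of the fluorine. Also open, as far as these compounds go, is whether the gap belongs to 1,3-thiazol-2-yl alone or extends to a 1,3-oxazol-2-yl or a methyl-bearing 1,3-thiazol-2-yl.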